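The source may report more compounds than this note shows. Statements on the series, on what has been measured and on what is new or still open speak of the compounds shown alone.

Compound 1 `Cc1cnc(Nc2ccc(C#N)cc2)nc1Nc1c(F)cc(-c2cccnc2)cc1F`: 1100 nM
Compound 2 `Cc1cnc(Nc2ccc(C#N)cc2)nc1Nc1c(F)cc(-c2ccsc2)cc1F`: 261000 nM
Compound 3 `Cc1cc(-c2ccnc3ccccc23)cc(C)c1Nc1ccnc(Nc2ccc(C#N)cc2)n1`: 3500 nM

These numbers come from a toxicity assay on MT4 cells (Homo sapiens) for cytotoxicity, read by MTT assay, with a stated time of 5 days; a higher number here means that more compound is tolerated, a lower number that less compound is tolerated. Compound 3 holds the middle place of the three: its value of 3500 nM lies closer to compound 1 at 1100 nM than to compound 2 at 261000 nM.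

The next compound is compound 4 `Cc1cc(-c2cc(C)c(Nc3ccnc(Nc4ccc(C#N)cc4)n3)c(C)c2)cc(C)n1`, made from compound 3 by one change: 2,6-dimethylpyridin-4-yl in place of quinolin-4-yl on an aromatic carbon. In words, 2,6-dimethylpyridin-4-yl stands in place of quinolin-4-yl, so the ring of carbon only leaves while a six-membered aromatic ring with a nitrogen stays.

Going by the values given here, only one measured step bears on this, and only loosely. Thiophen-3-yl in place of pyridin-3-yl gives a 240-fold higher number from compound 1 to compound 2 (2.38 log units; beyond the scatter), which is large and shows that the group at this kind of place can matter greatly in this assay. That step removes the ring nitrogen, however, whereas the change to compound 4 keeps one, and compound 1 and compound 3 share such a ring and both have much lower numbers than compound 2. The core of compound 3 also differs from that of compound 1, so the transfer is uncertain.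

A small rise is therefore expected, possibly no more than the scatter: the estimated step is a 1.7-fold higher number from compound 3 to compound 4 (0.23 log units; within the scatter). For compound 4 the estimated value is 6000 nM, with an expected range from 1800 nM to 25000 nM.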

Compound 4, half-maximal cytotoxic concentration: 2300 nM
Compound 4: middle estimate off by 2.6-fold (0.42 log units), on the high side; the measured number falls inside the stated range.
By their numbers in this assay, from the lowest: compound 1; then compounds 4 and 3 (each within the scatter of the next); then compound 2.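

In this assay the exchange of quinolin-4-yl for 2,6-dimethylpyridin-4-yl gives a 1.5-fold lower number from compound 3 to compound 4 (0.18 log units; within the scatter) and so leaves the number within the usual scatter, even though the carbon-only ring leaves and the entering group has fewer heavy atoms. Going by these compounds alone, the only earlier step at such a place, a 240-fold higher number from compound 1 to compound 2 (2.38 log units; beyond the scatter), was large, so the new step shows that the group on this aromatic carbon can also change substantially without any clear shift in the number, at least when a six-membered aromatic ring with a nitrogen stays on both sides. Nothing measured alongside these numbers explains why this exchange leaves the value so little changed.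

The compounds shown leave open whether the large step seen with thiophen-3-yl would recur on the core of compound 3, and what the methyl groups contribute, since plain pyridin-4-yl is not among them. They also leave open how the number would respond at this place to a group that is not an aromatic ring, such as an amine or a carboxylic acid.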